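The source may report more compounds than this note shows. Statements on the series, on what has been measured and on what is new or still open speak of the compounds shown alone.

Of the compounds shown here, three sharing one core have been measured in an assay on isolated protein for inhibition of Indoleamine 2,3-dioxygenase 1 (Homo sapiens), read by spectrophotometry, with a stated time of 1 h; a lower number here means a stronger inhibitor, a higher number a weaker inhibitor: compound 1 `O=[N+]([O-])c1ccc(N/C(=N\O)c2ccccc2Br)c2nonc12` gives 80 nM, compound 2 `O=[N+]([O-])c1ccc(N/C(=N\O)c2cccc(F)c2)c2nonc12` gives 75 nM, and compound 3 `O=[N+]([O-])c1ccc(N/C(=N\O)c2ccc(Cl)cc2)c2nonc12` gives 113 nM. Compound 3 has the highest of the three numbers, but its gaps to the others, a 1.4-fold higher number from compound 1 to compound 3 (0.15 log units; within the scatter) and a 1.5-fold higher number from compound 2 to compound 3 (0.18 log units; within the scatter), both lie within the scatter, as does a 1.1-fold lower number from compound 1 to compound 2 (0.03 log units; within the scatter). Compound 4 `O=[N+]([O-])c1ccc(N/C(=N\O)c2ccc(F)c(Cl)c2)c2nonc12` differs from compound 3 by 3-chloro-4-fluorophenyl in place of 4-chlorophenyl on a carbon with a double bond to nitrogen. All three measured steps exchange the aryl group on that same carbon, and none of them moved the number beyond the scatter, so no step beyond the scatter is expected for a 1.1-fold lower number from compound 3 to compound 4 (0.05 log units; within the scatter) in this assay. Compound 4 is therefore estimated at 100 nM, with a range of 50 nM to 200 nM.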

Compound 4, half-maximal inhibitory concentration: 158 nM
The estimate for compound 4 lay 1.6-fold (0.20 log units) below the measured number; measured number inside the range.
By their numbers in this assay, from the lowest: compounds 2, 1, 3 and 4 (each within the scatter of the next, the first and the last beyond it).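

The aryl group on the carbon with a double bond to nitrogen now gives its first step beyond the scatter in this assay, with a 2.1-fold higher number from compound 2 to compound 4 (0.32 log units; beyond the scatter), while a 1.4-fold higher number from compound 3 to compound 4 (0.15 log units; within the scatter) and a 2.0-fold higher number from compound 1 to compound 4 (0.30 log units; within the scatter) both stay within it. The change from 3-fluorophenyl to 3-chloro-4-fluorophenyl is thus the only one shown that separates two compounds, and only modestly. No available evidence accounts for this step.

Still open, as far as these compounds go, is whether an amine, a carboxylic acid or a longer chain in place of the aryl ring at this carbon would move the number further.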